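Ethoxycarbonyl to (methylsulfanyl)carbonyl on a piperidine carbamate

The compounds below may be only part of what the source reports. "The series", "measured", "known", "first", "only" and "open" are said of these compounds alone.

Measured compounds:
compound 1, `CC(C)(C)OC(=O)N1CCC(Oc2cccc3c2ccn3-c2ccc(S(C)(=O)=O)cc2)CC1`, 631 nM
compound 2, `CCOC(=O)N1CCC(Oc2ncnc3c2CCN3c2ccc(S(C)(=O)=O)cc2F)CC1`, 251 nM

In a functional assay on CHO-K1 cells for agonist activity at Glucose-dependent insulinotropic receptor (Homo sapiens), read by a luciferase reporter, with a stated time of 5 h (on this read-out lower numbers stand for an effect already at smaller amounts and higher numbers for an effect only at larger amounts of compound), compound 2 gives 251 nM, the lowest of the two numbers; compound 1 gives 631 nM, a gap beyond the usual scatter, but the two compounds differ in several places at once, so the pair tells only what its two values show. Compound 3, `CSC(=O)N1CCC(Oc2ncnc3c2CCN3c2ccc(S(C)(=O)=O)cc2F)CC1`, has not yet been measured. It differs from compound 2 in one place: methylsulfanyl in place of ethoxy on a carbonyl carbon. The change keeps the carbonyl and the ring nitrogen it sits on and swaps only the group on the other side of that carbonyl, from a three-atom to a two-atom chain with the same count of acceptors. Among the compounds with values here, no measured pair shows this change, so the step is estimated from the size of the change alone. Compound 3 is expected to stay close to compound 2 in this assay, the step of a 1.3-fold higher number from compound 2 to compound 3 (0.11 log units; within the scatter) being within or barely beyond the scatter, and the estimate for compound 3 is 320 nM with a range of 120 nM to 800 nM.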

Compound 3, half-maximal effective concentration: 251 nM
Compound 3: the middle estimate sits 1.3-fold (0.11 log units) above what was measured; the measured number falls inside the stated range.
By their numbers in this assay, from the lowest: compounds 2 and 3 (each within the scatter of the next); then compound 1.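

In this assay, within the data shown here, the exchange of ethoxy for methylsulfanyl on a carbonyl carbon gives no change at the digits printed from compound 2 to compound 3 (within the scatter) and so supplies the first reading of a single place, which compound 1 and compound 2, differing in several places at once, could not give. With the carbonyl and the amide-type nitrogen in a ring kept, the group on that carbonyl can go from ethoxy to methylsulfanyl with no difference beyond the scatter, though this one exchange says nothing about other groups at this place. Nothing measured here accounts for the two groups reading alike.

Going by these compounds, what stays open is how far this holds: a longer chain such as n-butoxy, or an amine such as dimethylamino, on the same carbonyl could read the same as ethoxy and methylsulfanyl or quite differently. On these data alone, it is also open whether the tert-butoxy group of compound 1 would read alike on the core of compound 2, and so how much of the gap between those two compounds belongs to that group and how much to the rest of the structure.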